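From Compound 2 to Compound 4: One Ring Replaced

This account rests on a few compounds, and the source may have more. Where it says the series, first, only, none or still open, it means among the compounds named here.

Of the compounds shown here, three have been tested in a functional assay on LM7 cells (Homo sapiens) for cytotoxicity, read by MTT assay, with a stated time of 72 h; a higher number here means a weaker inhibitor, a lower number a stronger inhibitor. Compound 1 `Cc1cc(C)n2nc(SCc3cc(=O)c4cc(Cl)ccc4o3)nc2n1` reaches only the limit of > 25000 nM, which is a boundary of the assay and not a number. Compound 3 `Cc1cc(C)n2nc(SCc3nnc(SCc4coc5ccccc5c4=O)s3)nc2n1` gives 2500 nM. Compound 2 `Nc1nc(SCc2coc3ccccc3c2=O)n[nH]1` gives 16900 nM, the highest of the two numbers, and its gap to compound 3 lies beyond the usual scatter. Compound 4 `Cc1nnc(SCc2coc3ccccc3c2=O)s1` differs from compound 2 in one place: 5-methyl-1,3,4-thiadiazol-2-yl in place of 5-amino-1H-1,2,4-triazol-3-yl on a sulfur. No step of this kind has been measured among these compounds. The number for compound 4 is expected to fall somewhat, as a 1.9-fold lower number from compound 2 to compound 4 (0.27 log units; within the scatter), though with wide uncertainty. Compound 4 is estimated at 9000 nM, between 2500 nM and 30000 nM.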

Compound 4, half-maximal inhibitory concentration: 430 nM
Estimate against measurement, compound 4: 21-fold (1.32 log units) above; measured number outside the range, below it.
By their numbers in this assay, from the lowest: compound 4; then compound 3; then compound 2. At a limit, above all of these: compound 1.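

In this assay, within the data shown here, replacing 5-amino-1H-1,2,4-triazol-3-yl with 5-methyl-1,3,4-thiadiazol-2-yl on the sulfur gives a 39-fold lower number from compound 2 to compound 4 (1.59 log units; beyond the scatter), the first single-place step here, and it shows that the number depends strongly on the ring at this position. The two rings match in heavy atoms and hydrogen-bond acceptors, but differ in ring atoms, substituent and hydrogen-bond donors. Nothing measured here explains why the step is so large.

Which of these differences matters remains open. An amine in place of the methyl on the thiadiazole ring would help separate the substituent from the ring.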